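Swapping a Bicyclic Group for a Methylcyclohexenyl Ring

This account rests on a few compounds, and the source may have more. Where it says the series, first, only, none or still open, it means among the compounds named here.

Going by the values given here, compound 2 `CC(C(=O)NCc1ccc(C(F)(F)F)nc1C1CC2CCC1C2)c1ccc(NS(C)(=O)=O)c(F)c1` stands lowest of the two numbers known in an assay on CHO cells for antagonist activity at transient receptor potential cation channel subfamily V member 1 (Homo sapiens), read by FLIPR and calcium flux (on this read-out lower numbers stand for stronger inhibition and higher numbers for weaker inhibition), where compound 2 gives 1.5 nM. Compound 1 `Cc1nc(C(F)(F)F)ccc1CNC(=O)C(C)c1ccc(NS(C)(=O)=O)c(F)c1` gives 387 nM in this assay, and the step of a 260-fold lower number from compound 1 to compound 2 (2.41 log units; beyond the scatter) shows how much this position matters. Compound 3 `CC1C=C(c2nc(C(F)(F)F)ccc2CNC(=O)C(C)c2ccc(NS(C)(=O)=O)c(F)c2)CCC1` differs from compound 2 by a group of 7 heavy atoms (7 carbon; one six-membered non-aromatic ring of carbon only) in place of a group of 7 heavy atoms (7 carbon; 2 five-membered non-aromatic rings of carbon only), on an aromatic carbon. Among the compounds with values here, only the step from compound 1 to compound 2 bears on this change, and it was large; since compound 3 keeps a group of matching size at the same place, the expected step of a 2.7-fold higher number from compound 2 to compound 3 (0.43 log units; beyond the scatter) is small. Compound 3 is therefore estimated at 4 nM, within 1 nM to 15 nM.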

Compound 3, inhibition constant: 0.2 nM
Compound 3: middle estimate off by 20-fold (1.30 log units), on the high side, and the stated range ends above it.
By their numbers in this assay, from the lowest: compound 3; then compound 2; then compound 1.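

Two groups with the same count of heavy atoms are not interchangeable at this position: in this assay the change to 3-methylcyclohex-1-en-1-yl gives a 7.5-fold lower number from compound 2 to compound 3 (0.88 log units; beyond the scatter) and so moves the number beyond the scatter. Set against the methyl group, the same ring gives a 1900-fold lower number from compound 1 to compound 3 (3.29 log units; beyond the scatter) and is the largest step among these compounds. No measurement at hand gives a reason for either step. Still open, going by these compounds, is what a plain cyclohexyl group or a phenyl ring would give at this place, and so whether the double bond or the methyl group of the new ring matters more.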